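Chloro on the aryl ring: compound 3 from compound 2

The compounds below may be only part of what the source reports. "The series", "measured", "known", "first", "only" and "open" are said of these compounds alone.

Measured so far:
compound 1, `CCOC(=O)c1nnc2n(c1=O)CCN2c1ccc(Cl)c(Cl)c1`: > 100000 nM
compound 2, `NNC(=O)c1nnc2n(c1=O)CCN2c1ccccc1`: > 100000 nM

In a functional assay on T47D cells (Homo sapiens) for inhibition, read by spectrophotometry and BrdU incorporation, with a stated time of 72 h (on this read-out higher numbers stand for weaker inhibition and lower numbers for stronger inhibition), compound 1 gives > 100000 nM, which is a limit of the assay and not a number. Compound 2 gives > 100000 nM in this assay, again a limit rather than a measured number. Within the data shown here, both values sit at the limit of > 100000 nM in this assay, at which 2 of the 2 values shown sit, so compound 2 stands at the limit alongside the only other value shown, and no order can be drawn between the two.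

Compound 3, `NNC(=O)c1nnc2n(c1=O)CCN2c1cccc(Cl)c1`, has not yet been measured in this assay. It differs from compound 2 by chloro in place of hydrogen on an aromatic carbon. Among the measured compounds shown here, no step between measured compounds is available to calibrate this change; the one other compound that carries chlorine, compound 1, also sits at the limit. Nothing in the series points to a gain, so the expected step in this assay is none beyond the scatter, estimated as a number no higher from compound 2 to compound 3 (the limit leaves the size open). Compound 3 is expected to remain at or near the limit, estimated at 100000 nM. The range expected for compound 3 runs from 30000 nM to 300000 nM.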

Compound 3, half-maximal inhibitory concentration: > 100000 nM
Compound 3 ended at the assay's limit (the forecaster's own chance of this, stated with the estimate: 85%); the middle value sits exactly at the limit.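

No step can be read from compound 2 to compound 3, as both stand at a limit of the assay and not at a number: the limit of > 100000 nM in this assay, at which 3 of the 3 values shown sit. The compounds shown leave open whether phenyl to 3-chlorophenyl changes inhibition at all, and which structures would give a measurable value.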